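The compounds below may be only part of what the source reports. "The series", "measured", "known", "first", "only" and "open" are said of these compounds alone.

Measured so far in a functional assay on the whole organism (Ear, strain Kunming) for inhibition, with Mus musculus as the target, with a stated time of 2 h, at a dose of 200 mg/kg by the oral route; on this read-out higher numbers stand for more inhibition at the one dose given (going by the name of the read-out) and lower numbers for less inhibition:
compound 1 `COc1ccc(/C=C/C(=O)c2ccc(O)cc2O)cc1` — 51.4%
compound 2 `Cc1ccc(/C=C/C(=O)c2ccc(O)cc2O)cc1` — "not active" (no number reported)
compound 3 `CN(C)c1ccc(/C=C/C(=O)c2ccc(O)cc2)cc1` — 17.3%

In this assay compound 3 stands lowest of the two numbers; the nearest is compound 1, which gives 51.4%, and that gap lies beyond the scatter. Compound 2 gives "not active" (no number reported), with no number to place.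

Compound 4 `CN(C)c1ccc(/C=C/C(=O)c2ccc(O)cc2O)cc1` is not yet measured. It differs from compound 3 in one place: hydroxy in place of hydrogen on an aromatic carbon. With this change compound 4 carries the core of compound 1. Going by the values given here, no measured pair shows this change alone, so its size in this assay is unknown. Compound 1 gives 51.4% on that core while compound 2 gives "not active" (no number reported), so the core alone does not fix the outcome.

For compound 4 a moderate rise in this assay is expected, a number 12.7 percentage points higher from compound 3 to compound 4 (beyond the scatter). Compound 4 is estimated at 30%, in the range 5% to 60%.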

Compound 4, a percentage reported as inhibition, in the whole organism at one dose (the size of the read-out at that dose, not a potency): 62.6%
The estimate for compound 4 lay 32.6 percentage points below the measured number; the measured number lies above the stated range.
By their numbers in this assay, from the lowest: compound 3; then compound 1; then compound 4.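

In this assay, the hydroxy ortho to a large group now has its first single-place step, a number 45.3 percentage points higher from compound 3 to compound 4 (beyond the scatter), so with dimethylamino in the series this position strongly affects inhibition at the one dose. On the shared core, dimethylamino in place of methoxy gives a smaller but real step, a number 11.2 percentage points higher from compound 1 to compound 4 (beyond the scatter). Nothing at hand explains either step.

From the compounds shown here alone, whether the hydroxy step carries over to methoxy or methyl compounds remains open. So does whether a fluorine or an amino group at this position would keep the gain.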